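This account rests on a few compounds, and the source may have more. Where it says the series, first, only, none or still open, it means among the compounds named here.

Measured so far:
compound 1 `C=CC(=O)NCc1coc(-c2c(N)ncnc2Nc2ccc(Oc3ccc(F)cc3)c(Cl)c2)n1` — > 1.66 h in an in vitro ADME assay on microsomes from liver (Canis lupus familiaris) for metabolic stability, tested at 5 uM; a higher number here means that the compound lasts longer, a lower number that the compound disappears faster
compound 2 `C=CC(=O)NCc1coc(-c2c(N)ncnc2Nc2ccc(Oc3ccccn3)c(Cl)c2)n1` — 0.4 h
compound 3 `C=CC(=O)NCc1coc(-c2c(N)ncnc2Nc2ccc(Oc3cccnc3)c(Cl)c2)n1` — 0.65 h

The value of compound 1 in this assay is a limit of the assay, not a number. Among the two plain numbers, compound 3 stands highest, with compound 2 nearest to it; the step of a 1.6-fold higher number from compound 2 to compound 3 (0.21 log units; within the scatter) lies within the scatter, so the two are not told apart.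

Compound 4 `C=CC(=O)NCc1coc(-c2c(N)ncnc2Nc2ccc(F)c(Cl)c2)n1` has not yet been measured in this assay. It differs from compound 3 in one place: fluoro in place of (pyridin-3-yl)oxy on an aromatic carbon. The measured steps that touch this part of the molecule are an at least 4.1-fold lower number from compound 1 to compound 2 (0.61 log units; beyond the scatter) and an at least 2.5-fold lower number from compound 1 to compound 3 (0.40 log units; beyond the scatter); both swap one ring for another on the oxygen, and both are beyond the scatter. None of them removes the whole group on the oxygen, as the change to compound 4 does, so they give only a loose guide. Since compound 1 sits at the limit (the limit of > 1.66 h in this assay, at which 1 of the 3 values shown sits), a group without a ring nitrogen went with a longer half-life here.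

Compound 4 is therefore expected to show a modestly higher number, a step of about a 1.8-fold higher number from compound 3 to compound 4 (0.27 log units; within the scatter), with a wide range. The estimate for compound 4 in this assay is 1.2 h, between 0.5 h and 2.5 h.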

Compound 4, half-life: 0.15 h
Compound 4: the middle estimate sits 8.0-fold (0.90 log units) above what was measured; the whole stated range lies above it.
By their numbers in this assay, from the lowest: compound 4; then compounds 2 and 3 (each within the scatter of the next). At a limit, above all of these: compound 1.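

The earlier compounds shown here only swapped one ring for another on the oxygen, whereas compound 4 shows what happens in this assay when the whole group on this aromatic carbon gives way to a single fluoro: a 4.3-fold lower number from compound 3 to compound 4 (0.64 log units; beyond the scatter) and a 2.7-fold lower number from compound 2 to compound 4 (0.43 log units; beyond the scatter). So although both pyridinyl ethers fell short of the 4-fluorophenoxy compound, each still goes with a longer half-life than fluoro alone, and the change from 4-fluorophenoxy gives the largest step in the set, an at least 11-fold lower number from compound 1 to compound 4 (1.04 log units; beyond the scatter). The value of compound 1 is a limit and not a number: the limit of > 1.66 h in this assay, at which 1 of the 4 values shown sits.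

The compounds shown leave open whether the longer half-life needs a whole ring on the oxygen, since a small ether such as methoxy or a plain phenoxy would test how much of the group is required. They also leave open what the oxygen link contributes and whether fluoro itself matters, questions that an amine link in place of the oxygen and a bare hydrogen on this carbon would address.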